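The compounds below may be only part of what the source reports. "The series", "measured", "known", "first", "only" and "open" are said of these compounds alone.

Measured so far:
compound 1 `COc1cc(NC(=O)c2cncc(N3CC4CC(C3)N4)c2)cc(OC)c1`: 0.985 nM
compound 2 `O=C(Nc1ccc(F)cc1F)c1cncc(N2CC3CC(C2)N3)c1`: 0.051 nM

In an assay on membranes from Cerebral cortex for displacement of a labelled ligand from Neuronal acetylcholine receptor; alpha4/beta2 (Rattus norvegicus) (a higher number here means a weaker inhibitor, a lower number a stronger inhibitor), compound 2 stands at the lowest of the two numbers; compound 1 sits well beyond the scatter of it. Compound 3 `O=C(NCc1ccccc1)c1cncc(N2CC3CC(C2)N3)c1` is not yet measured. It differs from compound 2 by benzyl in place of 2,4-difluorophenyl on an amide-type nitrogen. Among the compounds with values here, no step between two measured compounds covers a change of this kind, so the expectation rests on compound 2 alone. The step of a 39-fold higher number from compound 2 to compound 3 (1.59 log units; beyond the scatter) is expected to run toward a higher number, beyond the scatter. For compound 3 the estimate in this assay is 2 nM, within 0.2 nM to 20 nM.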

Compound 3, inhibition constant: 1.8 nM
Estimate against measurement, compound 3: 1.1-fold (0.05 log units) above, within the range that was stated.
By their numbers in this assay, from the lowest: compound 2; then compounds 1 and 3 (each within the scatter of the next).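

On the amide-type nitrogen in this assay, the step of a 35-fold higher number from compound 2 to compound 3 (1.55 log units; beyond the scatter) is large, so the group at this position strongly sets the reading. This holds even though 2,4-difluorophenyl and benzyl each carry one six-membered aromatic ring of carbon only and no net charge. No measured evidence bears on the reason for this step. Left open is whether unsubstituted phenyl or 2,4-difluorobenzyl on that nitrogen would read nearer compound 2 or compound 3, and how a longer chain such as 2-phenylethyl would read.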